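A few compounds are considered here, and "the series" means these few. Any claim that something is new, unique, unknown or untested is made for them only; others in the source may bear on it.

Compound 3 `C=CCn1c(=O)/c(=C\c2ccccc2C(F)(F)F)[nH]c(=O)/c1=C\c1ccccc1OC` gives 9500 nM in a functional assay on Huh-7 cells (Homo sapiens) for cytotoxicity, read by CCK-8 assay, with a stated time of 72 h (a higher number here means a weaker inhibitor, a lower number a stronger inhibitor), the second highest of three numbers: its nearest neighbour is compound 2 `C=CCn1c(=O)/c(=C\c2cccc(Cl)c2)[nH]c(=O)/c1=C\c1ccccc1OC` with 8900 nM, a pair that lies within the scatter, while compound 1 `C=CCn1c(=O)/c(=C\c2ccccc2F)[nH]c(=O)/c1=C\c1ccccc1OC` gives 31300 nM, the step of a 3.3-fold lower number from compound 1 to compound 3 (0.52 log units; beyond the scatter) being the widest here. Compound 4 `C=CCn1c(=O)/c(=C\c2cc(Br)ccc2F)[nH]c(=O)/c1=C\c1ccccc1OC` differs from compound 3 by 5-bromo-2-fluorophenyl in place of 2-(trifluoromethyl)phenyl on a double-bonded chain carbon bound to an aromatic carbon. Going by the values given here, two measured steps bear on it: a 3.5-fold lower number from compound 1 to compound 2 (0.55 log units; beyond the scatter) and a 3.3-fold lower number from compound 1 to compound 3 (0.52 log units; beyond the scatter), both leaving a 2-fluorophenyl behind, whereas compound 4 brings a fluoro back with a bromo added. No step beyond the scatter is therefore expected, a 1.3-fold higher number from compound 3 to compound 4 (0.10 log units; within the scatter). Compound 4 is expected to give 12000 nM in this assay, within a range from 5000 nM to 35000 nM.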

Compound 4, half-maximal inhibitory concentration: "not active" (no number reported)
Nothing numeric was reported for compound 4; no gap can be computed for the estimate.
By their numbers in this assay, from the lowest: compounds 2 and 3 (each within the scatter of the next); then compound 1.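

Going by these compounds alone, compound 4 is reported in this assay only as "not active", without a number, so no step from compound 3 to compound 4 can be read. Nothing given here explains this result. The compounds shown leave open how the bromo in compound 4 relates to its loss of a reported number.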